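From Compound 3 to Compound 4: a Difluorophenyl Replacement

This account rests on a few compounds, and the source may have more. Where it says the series, first, only, none or still open, it means among the compounds named here.

Three analogues sharing one core have been measured in a functional assay on K562 cells (Homo sapiens) for cytotoxicity, read by sulforhodamine B assay, with a stated time of 48 h, tested at 10 uM; on this read-out lower numbers stand for a stronger effect and higher numbers for a weaker effect at the one concentration tested. Compound 1 `COc1cc(-c2cc(/C=C/C(=O)c3ccc(N)cc3)[nH]n2)cc(OC)c1OC` gives 2%. Compound 2 `COc1cc(-c2cc(/C=C/C(=O)c3ccc(Cl)c(Cl)c3)[nH]n2)cc(OC)c1OC` gives 28%, and compound 3 `COc1ccc(C(=O)/C=C/c2cc(-c3cc(OC)c(OC)c(OC)c3)n[nH]2)cc1` gives -17%. That is the lowest of the three numbers, and the steps from compound 3 to both other compounds lie beyond the scatter; it stands as the strongest effect of the set. Two single-point steps frame it: a number 19 percentage points lower from compound 1 to compound 3 (beyond the scatter), and a number 45 percentage points lower from compound 2 to compound 3 (beyond the scatter). The second of these concerns the same carbonyl carbon and the same kind of exchange as the change now considered.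

Compound 4 `COc1cc(-c2cc(/C=C/C(=O)c3ccc(F)c(F)c3)[nH]n2)cc(OC)c1OC` differs from compound 3 in one place: 3,4-difluorophenyl in place of 4-methoxyphenyl on a carbonyl carbon. This runs in the reverse direction of the step from compound 2 to compound 3, with fluorine where compound 2 carries chlorine. On that basis a rise in this assay is expected for compound 4, likely smaller than the full size of the step just named. Compound 4 is therefore expected to show a number 32 percentage points higher from compound 3 to compound 4 (beyond the scatter), which amounts to an estimated 15%, with a range from -10% to 40%.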

Compound 4, a percentage reported as activity, at one concentration (the size of the read-out at that concentration, not a potency): 2%
For compound 4 the middle estimate is 13 percentage points above the measured one; the measured number falls inside the stated range.
By their numbers in this assay, from the lowest: compound 3; then compounds 1 and 4 (each within the scatter of the next); then compound 2.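

In this assay, among the compounds shown here, the halogen pattern on the carbonyl carbon turns out not to be interchangeable: keeping the 3,4-substitution but exchanging chlorine for fluorine gives a number 26 percentage points lower from compound 2 to compound 4 (beyond the scatter), a contrast between two halogens that the earlier compounds could not offer. The 3,4-difluorophenyl group does not match the 4-methoxyphenyl group, with a number 19 percentage points higher from compound 3 to compound 4 (beyond the scatter), while against the 4-aminophenyl group there is no change at the digits printed from compound 1 to compound 4 (within the scatter), so a ring with no hydrogen-bond donor or acceptor reads level with the amino-bearing ring, and the 4-methoxyphenyl analogue remains the strongest of the four. Nothing available here explains these differences, so the reason for them remains unknown.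

The compounds shown leave open how a 4-fluorophenyl, a 4-ethoxyphenyl or a 3,4-dimethoxyphenyl group would read at this carbonyl carbon, and so whether the low number belongs to the methoxy group itself or to a wider family of groups. From the compounds shown here alone, all four also keep the rest of the shared core unchanged, so it remains open whether this order would hold with a longer alkoxy chain in place of the three methoxy groups there.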